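Replacing 1-hydroxy-1-methylethyl with (azetidin-3-yl)carbonyl

This account rests on a few compounds, and the source may have more. Where it says the series, first, only, none or still open, it means among the compounds named here.

Compound 1 `O=C(c1ccc(-c2ccc(N3C[C@H](Cn4ccnn4)OC3=O)cc2F)cn1)C1CCNCC1` gives 100000 nM
Compound 2 `CC(C)(O)c1ccc(-c2ccc(N3C[C@H](Cn4ccnn4)OC3=O)cc2F)cn1` gives 200000 nM

Within the data shown here, in a physicochemical assay for solubility, read by nephelometry (on this read-out lower numbers stand for lower solubility and higher numbers for higher solubility), compound 2 stands at 200000 nM and cannot be separated from its only measured neighbour. Among the measured compounds shown here, the single measured step is a 2.0-fold higher number from compound 1 to compound 2 (0.30 log units; within the scatter) and it bears directly on what follows.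

Compound 3 `O=C(c1ccc(-c2ccc(N3C[C@H](Cn4ccnn4)OC3=O)cc2F)cn1)C1CNC1` has not been measured. It carries (azetidin-3-yl)carbonyl in place of the 1-hydroxy-1-methylethyl of compound 2 on an aromatic carbon. Counted out, the change is (azetidin-3-yl)carbonyl in place of 1-hydroxy-1-methylethyl on an aromatic carbon and it sits next to the ring nitrogen.

Compound 1 also carries a carbonyl-linked ring, (piperidin-4-yl)carbonyl, and stands at 100000 nM so it is the closest guide. No step beyond the scatter is therefore expected in this assay and any drift should be slightly towards a lower number. The expected size is a 1.7-fold lower number from compound 2 to compound 3 (0.22 log units; within the scatter) by this estimate. For compound 3 the estimated value is 120000 nM with an expected range from 50000 nM to 250000 nM around it.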

Compound 3, solubility: 200000 nM
Beside the measured number, compound 3's estimate is 1.7-fold (0.22 log units) below it; the range from low to high includes it.
By their numbers in this assay, from the lowest: compounds 1, 2 and 3 (each within the scatter of the next).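

At the aromatic carbon next to the ring nitrogen, this assay gives no change at the digits printed from compound 2 to compound 3 (within the scatter), so (azetidin-3-yl)carbonyl and 1-hydroxy-1-methylethyl cannot be told apart, although one carries a four-membered ring and the other has no ring. The change on the carbonyl carbon gives a 2.0-fold higher number from compound 1 to compound 3 (0.30 log units; within the scatter), so azetidin-3-yl and piperidin-4-yl cannot be told apart in this assay either. Nothing available explains these results.

All three compounds lie within the scatter of one another, which leaves open whether any group at this position can move the read-out beyond the scatter. A carboxylic acid or an open-chain amine in the same place would test this with a group of a different kind.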